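This account rests on a few compounds, and the source may have more. Where it says the series, first, only, none or still open, it means among the compounds named here.

In an assay on isolated protein for inhibition of RAC-alpha serine/threonine-protein kinase (Homo sapiens) (a higher number here means a weaker inhibitor, a lower number a stronger inhibitor), compound 3 `Cc1cccc(C)c1S(=O)(=O)NC[C@@H](O)CN1CCC[C@@]2(CCN(c3ncnc(N)c3C3CC3)C2)C1` gives 4 nM. That is the lowest of the three numbers recorded so far: compound 1 `CCOCCN(C[C@@H](O)CN1CCCC2(CCN(c3ncncc3C3CC3)C2)C1)S(=O)(=O)c1c(C)cccc1C` gives 12 nM in this assay, and compound 2 `Cc1cccc(C)c1S(=O)(=O)N1CCC[C@@H]1[C@@H](O)CN1CCC[C@@]2(CCN(c3ncnc(N)c3C3CC3)C2)C1` gives 19 nM, and both of these steps up from compound 3 lie beyond the scatter, so compound 3 is the strongest inhibitor of the three that have been measured.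

Compound 4 `Cc1noc(C)c1S(=O)(=O)NC[C@@H](O)CN1CCC[C@@]2(CCN(c3ncnc(N)c3C3CC3)C2)C1` has not yet been measured. It differs from compound 3 in a single place: 3,5-dimethyl-1,2-oxazol-4-yl in place of 2,6-dimethylphenyl on a sulfonyl sulfur. The shared core, the hydroxyl-bearing chain and the sulfonamide are unchanged.

Among the measured compounds shown here, none of the measured pairs shows this kind of exchange, so there is no step to lean on. With the two methyl groups retained and only the aromatic ring exchanged, he expects a small step toward a weaker inhibitor, at most just beyond the scatter, and possibly none at all. He therefore estimates that compound 4 gives about 8 nM in this assay, in a range from 2.5 nM to 30 nM. The step of a 2.0-fold higher number from compound 3 to compound 4 (0.30 log units; within the scatter) is thus his expectation, not a measurement.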

Compound 4, half-maximal inhibitory concentration: 3 nM
The estimate for compound 4 lay 2.7-fold (0.43 log units) above the measured number; the range from low to high includes it.
By their numbers in this assay, from the lowest: compounds 4 and 3 (each within the scatter of the next); then compounds 1 and 2 (each within the scatter of the next).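

In this assay, 3,5-dimethyl-1,2-oxazol-4-yl in place of 2,6-dimethylphenyl on a sulfonyl sulfur gives a 1.3-fold lower number from compound 3 to compound 4 (0.12 log units; within the scatter) and so leaves the reading unchanged within the scatter. Among the compounds shown here, all the earlier compounds carry 2,6-dimethylphenyl on this sulfur, so they could not show that a five-membered aromatic ring with 2 hetero atoms serves here as well as a six-membered aromatic ring of carbon only. Nothing in the data given accounts for this match between the two groups.

On these data alone, it remains open whether this position needs an aromatic ring with two methyl groups at all, or whether an unsubstituted phenyl ring or a plain methyl group on the sulfonyl sulfur would read the same. Also open, as far as these compounds go, is whether the same exchange would hold on the sulfonamide of compound 1 or compound 2.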